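This account rests on a few compounds, and the source may have more. Where it says the series, first, only, none or still open, it means among the compounds named here.

In a physicochemical assay for lipophilicity, using the shake flask method (on this read-out higher numbers stand for higher lipophilicity and lower numbers for lower lipophilicity), compound 1 (`C[C@H](Oc1ccc2ncc(/C=C/C(=O)O)cc2c1)c1c(Cl)ccc(F)c1Cl`) gives 2.5, the lowest of three measured numbers. Compound 2 (`C[C@H](Oc1ccc2nnc(/C=C/C(=O)O)c(C3CC3)c2c1)c1c(Cl)ccc(F)c1Cl`) gives 3.2 and compound 3 (`C[C@H](Oc1ccc2ccc(/C=C/c3nn[nH]n3)c(C3CC3)c2c1)c1c(Cl)cccc1Cl`) gives 4.3. Both numbers are higher than that of compound 1, and both gaps exceed the usual scatter. Going by the values given here, these compounds differ in more than one place, so no measured pair isolates a single change. Compound 4 (`C[C@H](Oc1ccc2ncc(/C=C/C(=O)O)c(O)c2c1)c1c(Cl)ccc(F)c1Cl`) carries one change from compound 1: hydroxy in place of hydrogen on an aromatic carbon, opposite the ring nitrogen. A moderate drop in this assay, beyond the scatter, is expected, though no measurement here tests this change. The estimated step is a number 0.60 log units lower from compound 1 to compound 4 (beyond the scatter). For compound 4 the expected value is 1.9, with an estimated range from 1.2 to 2.6.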

Compound 4, distribution coefficient: 1.9
The estimate for compound 4 equals the measured number at the digits printed; low and high end bracket the measured number.
By their numbers in this assay, from the lowest: compound 4; then compound 1; then compound 2; then compound 3.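

Going by these compounds alone, earlier compounds differed in more than one place, so this is the first single change that can be read on its own: in this assay, hydroxy in place of hydrogen on this aromatic carbon, opposite the ring nitrogen, gives a number 0.60 log units lower from compound 1 to compound 4 (beyond the scatter). At this position, ortho to a 2-carboxyethenyl group, one added oxygen atom is thus enough to move the number beyond the scatter. Nothing measured here explains the step. The compounds shown leave open how a methoxy group or an amine on this same carbon would read, and whether hydroxy on another aromatic carbon of the core would give a similar step.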